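This account rests on a few compounds, and the source may have more. Where it says the series, first, only, none or still open, it means among the compounds named here.

In an ADME assay on the whole organism for inhibition, with Echinochloa crus-galli var. formosensis as the target, with a stated time of 4 days (a higher number here means a weaker inhibitor, a lower number a stronger inhibitor), three compounds on the shared core have been measured. Compound 1 `CC[C@H](C)Nc1nc(Cl)nc(N[C@@H](C)c2ccccc2)n1` gives 14100 nM, compound 2 `C[C@H](Nc1nc(Cl)nc(NC(C)(C)C)n1)c1ccccc1` gives 7410 nM and compound 3 `CC[C@@H](C)Nc1nc(Cl)nc(N[C@@H](C)c2ccccc2)n1` gives 7410 nM. Compound 3 is therefore level with compound 2 at the digits shown and within the scatter of compound 1.

Compound 4 `CCCN(C)c1nc(Cl)nc(N[C@@H](C)c2ccccc2)n1` is still unmeasured. The change is methyl(propyl)amino in place of (sec-butyl)amino on an aromatic carbon, on an aromatic carbon between two ring nitrogen atoms.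

Three measured steps alter the substituent on this amino nitrogen. Swapping the branched group gives a 1.9-fold lower number from compound 1 to compound 2 (0.28 log units; within the scatter) and, in the other pairing, no change at the digits printed from compound 2 to compound 3 (within the scatter). Inverting one stereocentre gives a 1.9-fold lower number from compound 1 to compound 3 (0.28 log units; within the scatter), the only structural difference there being (the fact that compounds 1 and 3 differ only in the configuration as drawn). None of these steps changes the hydrogen-bond donor count, so none sets a size for the new change directly.

With compound 3 flanked by steps such as a 1.9-fold lower number from compound 1 to compound 3 (0.28 log units; within the scatter), a large move is not expected, but the untested change calls for a wide range. A modest shift towards a higher number is expected, on thin evidence: a 2.0-fold higher number from compound 3 to compound 4 (0.31 log units; beyond the scatter). The estimate for compound 4 is 15000 nM, with an expected range of 5000 nM to 50000 nM.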

Compound 4, half-maximal inhibitory concentration: 380 nM
Beside the measured number, compound 4's estimate is 39-fold (1.60 log units) above it; the whole stated range lies above it.
By their numbers in this assay, from the lowest: compound 4; then compounds 2, 3 and 1 (each within the scatter of the next).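

In this assay, within the data shown here, the aromatic carbon between two ring nitrogen atoms proves far more sensitive to the amine substituent than the earlier compounds could show: a 20-fold lower number from compound 3 to compound 4 (1.29 log units; beyond the scatter), a 20-fold lower number from compound 2 to compound 4 (1.29 log units; beyond the scatter) and a 37-fold lower number from compound 1 to compound 4 (1.57 log units; beyond the scatter), while the steps among compounds 1, 2 and 3 all stayed within the scatter. Compound 4 is thus the strongest inhibitor of the four, and the size of the step does not follow from the size of the group, as methyl(propyl)amino and (sec-butyl)amino both have 5 heavy atoms. What the counts do separate is 1 hydrogen-bond donor and 1 defined stereocentre in (sec-butyl)amino against 0 hydrogen-bond donors in methyl(propyl)amino, but nothing at hand gives a cause for this step.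

The compounds shown leave open whether the step follows the loss of the amino hydrogen or the unbranched propyl chain, a question that propylamino and dimethylamino groups at this position would bear on. Also open, going by these compounds, is how far the step extends to a longer chain such as methyl(butyl)amino, or to a cyclic amine such as pyrrolidine.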